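The source may report more compounds than this note shows. Statements on the series, on what has been measured and on what is new or still open speak of the compounds shown alone.

Three compounds built on the shared core were tested in a functional assay on MCF7 cells (Homo sapiens) for cytotoxicity, read by MTT assay, with a stated time of 72 h; on this read-out higher numbers stand for weaker inhibition and lower numbers for stronger inhibition. Compound 1 `COc1cccc(/C=C2\CCC/C(=C\c3ccc(Cl)c(Cl)c3)C2=O)c1OC` gives 9000 nM. Compound 2 `COc1cccc(/C=C2\CCC/C(=C\c3cc(OC)c(OC)c(OC)c3)C2=O)c1OC` gives 1400 nM. Compound 3 `COc1ccc(/C=C2\CCC/C(=C\c3ccccc3Cl)C2=O)cc1OC` gives 10400 nM, the highest of the three numbers; its gap to compound 1 lies within the scatter, so those two cannot be ordered, while compound 2 sits beyond the scatter at a lower number. Compound 4 `COc1ccc(/C=C2\CCC/C(=C\c3ccc(Cl)cc3Cl)C2=O)cc1OC` has not yet been measured. It differs from compound 3 in one place: chloro in place of hydrogen on an aromatic carbon. Cut one bond further out, the change reads 2-chlorophenyl to 2,4-dichlorophenyl. Within the data shown here, no measured pair shows this same change, so its effect is unknown from direct data. Compound 1, whose arm carries two chloro groups, gives 9000 nM, a number within the scatter of compound 3, which hints that a second chloro alters little here. A step of a 1.3-fold lower number from compound 3 to compound 4 (0.11 log units; within the scatter) is expected, one that need not exceed the scatter. The estimate for compound 4 is 8000 nM, within 3000 nM to 20000 nM.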

Compound 4, half-maximal inhibitory concentration: 16200 nM
Compound 4: middle estimate off by 2.0-fold (0.31 log units), on the low side; the measured number falls inside the stated range.
By their numbers in this assay, from the lowest: compound 2; then compounds 1, 3 and 4 (each within the scatter of the next).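

In this assay, among these compounds, putting a chloro group in place of hydrogen on the 2-chlorophenyl arm, para to a large group and meta to the existing chloro group, gives a 1.6-fold higher number from compound 3 to compound 4 (0.19 log units; within the scatter) and provides the first direct reading of this change. On this single pair, the step from 2-chlorophenyl to 2,4-dichlorophenyl does not separate the two compounds, so neither can be called the stronger inhibitor of the pair. No supporting measurement is available to explain this result.

A single chloro group at this position says little about how other groups would read there, such as an amine or a carboxylic acid. From the compounds shown here alone, it also remains open whether the same chloro change would give a similar step on a different arm or with a different substitution pattern on the shared core.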